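Hydrogen in place of fluoro on a short-lived compound

The source may hold more compounds than are shown below. What is called first, only, known or untested is meant among the compounds shown, and "the series" means these compounds.

Measured in an ADME assay on microsomes from liver (Homo sapiens) for metabolic stability, read by LC-MS, tested at 1 uM; a higher number here means that the compound lasts longer, a lower number that the compound disappears faster:
- Compound 1 `O=C(Nc1ccc(F)c(-c2nc3ncccc3o2)c1)c1cnco1`: 2.07 h
- Compound 2 `Cc1ccoc1C(=O)Nc1ccc(F)c(-c2nc3ncccc3o2)c1`: 0.15 h

Compound 2 holds the lower of the two numbers, so it disappears faster than compound 1. The next compound, compound 3 `Cc1ccoc1C(=O)Nc1cccc(-c2nc3ncccc3o2)c1`, is still unmeasured. It differs from compound 2 in one place: hydrogen in place of fluoro on an aromatic carbon. In short, hydrogen stands in place of fluoro on an aromatic carbon. Among the measured compounds shown here, the only measured step is a 14-fold lower number from compound 1 to compound 2 (1.14 log units; beyond the scatter), which is large. That step is a different change, however: 3-methylfuran-2-yl in place of 1,3-oxazol-5-yl on a carbonyl carbon. For the measured compounds named here, both of its compounds carry the fluoro group, so no measured pair shows what losing it does. Without such evidence, no step beyond the scatter is expected in this assay. The expected step is a 1.2-fold lower number from compound 2 to compound 3 (0.06 log units; within the scatter). For compound 3 the estimated value is 0.13 h, with an expected range of 0.06 h to 0.3 h.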

Compound 3, half-life: 0.167 h
The estimate for compound 3 lay 1.3-fold (0.11 log units) below the measured number, and the stated range covers the measured number.
By their numbers in this assay, from the lowest: compounds 2 and 3 (each within the scatter of the next); then compound 1.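

Hydrogen in place of fluoro on this aromatic carbon gives a 1.1-fold higher number from compound 2 to compound 3 (0.05 log units; within the scatter) in this assay. With the 3-methylfuran-2-yl group on the carbonyl carbon, the fluoro group can therefore leave this position without a step beyond the scatter, so the pair gives no sign that this one atom matters for how long the compound lasts. Nothing at hand offers an explanation for this result.

Compound 1 carries the 1,3-oxazol-5-yl group instead, and the pair leaves open whether the same swap would stay as small alongside that group. It also leaves open what a larger or different group on this aromatic carbon, such as a chlorine atom, a methoxy group or an amine, would do to the number.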